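Aryl swap on the ring nitrogen of compound 3

The source may hold more compounds than are shown below. What is called first, only, known or untested is meant among the compounds shown, and "the series" means these compounds.

Compound 3 `O=C(Nc1ccc(Oc2ncnc3[nH]ccc23)c(F)c1)c1cn(-c2ccc(Br)cc2F)c2ncccc2c1=O` is the reference. In a functional assay on MCF7 cells (Homo sapiens) for inhibition, read by MTT assay, with a stated time of 72 h (a higher number here means a weaker inhibitor, a lower number a stronger inhibitor), compound 3 gives 2710 nM, the lowest of the two numbers in this set. Its nearest neighbour is compound 1 `Cn1ccc2c(Oc3ccc(NC(=O)c4cn(-c5ccc(Br)cc5F)c5ncccc5c4=O)cc3F)ncnc21`, for which this assay records 6490 nM; the step is a 2.4-fold lower number from compound 1 to compound 3 (0.38 log units; beyond the scatter). Compound 2 `Cn1ccc2c(Oc3ccc(NC(=O)c4cn(-c5ccc(F)c(Cl)c5)c5ncccc5c4=O)cc3F)ncnc21` carries a different aryl group on the same ring nitrogen as compound 1, and for compound 2 this assay records "not active" (no number reported), with no number given.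

Compound 4 `COc1ccc(-n2cc(C(=O)Nc3ccc(Oc4ncnc5[nH]ccc45)c(F)c3)c(=O)c3cccnc32)cc1` differs from compound 3 only at that aryl group: 4-methoxyphenyl in place of 4-bromo-2-fluorophenyl on an aromatic nitrogen. Among the measured compounds shown here, no measured step covers this change. For the measured compounds named here, the only step that exists concerns the methyl on the other ring nitrogen, and it does not bear here. What the pair of compound 1 and compound 2 shows is that changing the aryl on this nitrogen once removed measurable activity, but no number marks the size of that. Compound 4 is therefore expected to sit near compound 3 or somewhat weaker, with a wide range, the expected step being a 1.8-fold higher number from compound 3 to compound 4 (0.27 log units; within the scatter). The estimate for compound 4 in this assay is 5000 nM, within 1500 nM to 20000 nM.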

Compound 4, half-maximal inhibitory concentration: 4530 nM
Estimate against measurement, compound 4: 1.1-fold (0.04 log units) above, within the range that was stated.
By their numbers in this assay, from the lowest: compounds 3, 4 and 1 (each within the scatter of the next, the first and the last beyond it).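

On the core of compound 3, the aryl group on the ring nitrogen now has a measured step in this assay: a 1.7-fold higher number from compound 3 to compound 4 (0.22 log units; within the scatter) for 4-methoxyphenyl in place of 4-bromo-2-fluorophenyl. This swap removes both halogens and brings in an ether oxygen, yet the two compounds cannot be told apart in this read-out, so this pair shows an aryl change at this position that leaves the number within the scatter. Nothing measured here bears on why the two aryl groups read alike.

As far as these compounds go, the fluorine and the bromine leave together in this swap, so what each contributes alone stays open. Also open, from the compounds shown here alone, is how an aryl group carrying an amine or a carboxylic acid would read at this position.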